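The source may hold more compounds than are shown below. What is called first, only, known or untested is meant among the compounds shown, and "the series" means these compounds.

Compound 1, `COc1ccc(C2=NO[C@]3(C2)C(=O)O[C@@H]2[C@H]3CC[C@H](C)[C@]3(O)C=CC(=O)[C@@]23C)cc1`, gives 35000 nM in a functional assay on PC-3 cells (Homo sapiens) for cytotoxicity, read by sulforhodamine B assay, with a stated time of 48 h; a lower number here means a stronger inhibitor, a higher number a weaker inhibitor.
Compound 2, `C[C@H]1CC[C@@H]2[C@@H](OC(=O)[C@]23CC(c2ccccc2)=NO3)[C@]2(C)C(=O)C=C[C@@]12O`, gives 46000 nM.
Compound 3, `C[C@H]1CC[C@@H]2[C@@H](OC(=O)[C@]23CC(c2ccccc2[N+](=O)[O-])=NO3)[C@]2(C)C(=O)C=C[C@@]12O`, gives 37000 nM.

Compound 3 has the second highest of the three numbers, and its gaps to compound 1 and compound 2 both fall within the scatter. Compound 4, `C[C@H]1CC[C@@H]2[C@@H](OC(=O)[C@]23CC(c2ccccc2Cl)=NO3)[C@]2(C)C(=O)C=C[C@@]12O`, differs from it by chloro in place of nitro on an aromatic carbon. Among the measured compounds shown here, two measured steps touch the same part of the molecule: the change a 1.2-fold lower number from compound 2 to compound 3 (0.09 log units; within the scatter), and the wider swap a 1.1-fold higher number from compound 1 to compound 3 (0.02 log units; within the scatter); neither moved the number beyond the scatter. The step of a 1.0-fold higher number from compound 3 to compound 4 (0.01 log units; within the scatter) is therefore expected to stay within the scatter as well. For compound 4 in this assay the estimate is 38000 nM, with a range from 19000 nM to 76000 nM.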

Compound 4, half-maximal inhibitory concentration: 12000 nM
The estimate for compound 4 lay 3.2-fold (0.50 log units) above the measured number; the measured number lies below the stated range.
By their numbers in this assay, from the lowest: compound 4; then compounds 1, 3 and 2 (each within the scatter of the next).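

In this assay, chloro in place of nitro (a 3.1-fold lower number from compound 3 to compound 4 (0.49 log units; beyond the scatter)) and chloro in place of hydrogen (a 3.8-fold lower number from compound 2 to compound 4 (0.58 log units; beyond the scatter)) both move the number beyond the scatter, though modestly, as does 2-chlorophenyl in place of 4-methoxyphenyl (a 2.9-fold lower number from compound 1 to compound 4 (0.46 log units; beyond the scatter)). This aromatic position therefore does respond to substitution: nitro left the number within the scatter of hydrogen, while chloro lowers it, so the identity of the entering group matters. Nothing available explains why chloro and nitro differ here.

From the compounds shown here alone, whether bromo, an amine or a carboxylic acid at this position would behave like chloro remains open. So does whether chloro would have the same effect on another carbon of the ring.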